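The source may hold more compounds than are shown below. What is called first, only, known or untested is meant among the compounds shown, and "the series" means these compounds.

Compound 1 `CCc1ccc(SCc2ccc(/C=C/C(=O)Nc3ccccc3N)cc2)cc1`: 13.2%
Compound 2 `Nc1ccccc1NC(=O)c1ccc(CSc2cccc(F)c2)cc1`: 18.6%
Compound 3 `Nc1ccccc1NC(=O)c1ccc(CSc2ccc(C(F)(F)F)cn2)cc1`: 12.4%

In a functional assay on SMMC-7721 cells (Homo sapiens) for inhibition, read by CCK-8 assay, with a stated time of 72 h, tested at 2 uM (on this read-out lower numbers stand for less inhibition of growth and higher numbers for more inhibition of growth at the one concentration tested), compound 2 gives 18.6%. That number lies within the scatter of the values for both compound 1 and compound 3, so the data set no order among the three, and compound 2 stands level with the other two.

The next compound to be tested is compound 4 `Nc1ccccc1NC(=O)c1ccc(CSc2ccc(F)cc2)cc1`. It has 4-fluorophenyl in place of 3-fluorophenyl on a sulfur. The two structures have the same atoms, joined differently.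

Within the data shown here, no pair of measured compounds differs in one place only, so the data hold no direct measure of a change of this kind. Among the measured compounds shown here, the only guide is the spread of the values. The structure differs between compound 2 and compound 1, and compound 1 gives 13.2%. Compound 3, also different, gives 12.4%. Both stay within the scatter of compound 2, which suggests that a smaller change would not stand out either.

The expected step of a number 2.6 percentage points lower from compound 2 to compound 4 (within the scatter) is therefore none beyond the scatter, with no direction that could be called. For compound 4 the estimated value in this assay is 16%, with an expected range from 6% to 28%.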

Compound 4, percent growth inhibition at one concentration: 6.58%
Estimate against measurement, compound 4: 9.4 percentage points above, within the range that was stated.
By their numbers in this assay, from the lowest: compounds 4, 3, 1 and 2 (each within the scatter of the next, the first and the last beyond it).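

Among these compounds, for the first time the series holds a pair that differs in one place only: with 4-fluorophenyl in place of 3-fluorophenyl on the sulfur, this assay shows a number 12 percentage points lower from compound 2 to compound 4 (beyond the scatter) in the read-out. The earlier compounds shown here could not show this, as their values all lay within the scatter of one another, whereas here the two groups have the same atoms, joined differently, and the result still moves beyond the scatter. This position on the sulfur therefore responds to where the fluorine stands on the phenyl ring, but nothing in the data accounts for the step.

Whether this step belongs to fluorine in particular stays open, since the compounds shown do not reveal what a chlorine atom, a methoxy group or an amine would do on the same phenyl ring. On these data alone, it also remains unknown whether the same change would give a step of similar size on the longer core of compound 1, and a single tested concentration cannot show how the pair would compare across a range of concentrations.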